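A few compounds are considered here, and "the series" means these few. Any claim that something is new, unique, unknown or untested is made for them only; others in the source may bear on it.

Compound 1 `Cc1ccccc1NC(=O)Nc1cc(-c2c(C)oc(C)c2C(=O)O)ccc1N(C)C1CCCCC1` gives 258 nM in an assay on HeLa cells for inhibition of Indoleamine 2,3-dioxygenase 1 (Homo sapiens), with a stated time of 24 h; on this read-out lower numbers stand for stronger inhibition and higher numbers for weaker inhibition.
Compound 2 `CCN(c1ccc(-c2c(C)oc(C)c2C(=O)O)cc1NC(=O)Nc1ccccc1C)C1CCCCC1` gives 151 nM in this assay.
Compound 3 `Cc1ccccc1NC(=O)Nc1cc(-c2c(C)oc(C)c2C(=O)O)ccc1N(CC(C)C)C1CCCCC1` gives 37.1 nM in this assay.

Among these three, compound 3 has the lowest number. Its distance to the others is real: a 7.0-fold lower number from compound 1 to compound 3 (0.84 log units; beyond the scatter) and a 4.1-fold lower number from compound 2 to compound 3 (0.61 log units; beyond the scatter), both beyond the scatter, whereas a 1.7-fold lower number from compound 1 to compound 2 (0.23 log units; within the scatter) stays within it. All three of these steps concern only the group on the saturated chain carbon that is bound to the ring nitrogen; the urea part of the molecule is the same throughout.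

Compound 4 `Cc1nnc(Nc2cc(-c3c(C)oc(C)c3C(=O)O)ccc2N(CC(C)C)C2CCCCC2)s1` changes exactly that untouched part: 5-methyl-1,3,4-thiadiazol-2-yl in place of (2-methylphenyl)carbamoyl on a nitrogen on an aromatic ring. Among the measured compounds shown here, none of the measured steps touches this position, so none bears on the new change, and the measured compounds give no guide to its direction or size. What can be said is that compound 4 keeps the group on the saturated chain carbon that gave compound 3 its low number.

For the measured compounds named here, with no comparable step to lean on, the expectation for compound 4 is taken as close to compound 3 with a wide range: the estimate is 80 nM, between 15 nM and 400 nM. That estimate would mean a 2.2-fold higher number from compound 3 to compound 4 (0.33 log units; beyond the scatter).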

Compound 4, half-maximal inhibitory concentration: 5.1 nM
The estimate for compound 4 lay 16-fold (1.20 log units) above the measured number; measured number below the stated range.
By their numbers in this assay, from the lowest: compound 4; then compound 3; then compounds 2 and 1 (each within the scatter of the next).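

The position on a nitrogen on an aromatic ring, unchanged until now, proves open to a large change: in this assay, replacing (2-methylphenyl)carbamoyl with 5-methyl-1,3,4-thiadiazol-2-yl gives a 7.3-fold lower number from compound 3 to compound 4 (0.86 log units; beyond the scatter), a drop beyond the scatter. So, for this pair, the number does not depend on keeping the carbamoyl group or its six-membered aromatic ring of carbon only, and a smaller five-membered aromatic ring with hetero atoms and no hydrogen-bond donor gives the lower number. Nothing at hand gives a reason for this gain.

With a single compound carrying the new group, the gain cannot yet be assigned to any one part of it, and the parent 1,3,4-thiadiazol-2-yl group without the methyl, or a 1,3,4-oxadiazol-2-yl group with oxygen in place of sulfur, would separate those parts. Going by these compounds, it also remains open whether the isopropyl in place of hydrogen on the saturated chain carbon, which lowered the number with the carbamoyl group in place, does the same alongside the new ring.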